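Methyl ester to primary amide on the shared core

A few compounds are considered here, and "the series" means these few. Any claim that something is new, unique, unknown or untested is made for them only; others in the source may bear on it.

Compound 2 `COC(=O)c1ccc(-c2cnc(N)c(-c3ccc(C(F)(F)F)cc3)n2)cc1` stands at the bottom of the numbers shown. In a physicochemical assay for solubility, read by HPLC, using the shake flask method, with a stated time of 2 h, at pH 2 (on this read-out higher numbers stand for higher solubility and lower numbers for lower solubility), compound 2 gives < 5000 nM, which is a limit of the assay and not a number. Compound 1 `Nc1ncc(-c2ccc(C(=O)N3CCC(N)C3)cc2)nc1-c1ccc(C(F)(F)F)cc1` gives 165000 nM in this assay. The measured step of an at least 33-fold lower number from compound 1 to compound 2 (1.51 log units; beyond the scatter) is the only one on record; it reads methoxy in place of 3-aminopyrrolidin-1-yl on a carbonyl carbon, and it meets the floor of the assay, as the limit of < 5000 nM in this assay, at which 1 of the 2 values shown sits, shows, so its true size is open at the low end.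

Compound 3 `NC(=O)c1ccc(-c2cnc(N)c(-c3ccc(C(F)(F)F)cc3)n2)cc1` differs from compound 2 by amino in place of methoxy on a carbonyl carbon. Among the measured compounds shown here, no measured step replaces methoxy with amino on that carbonyl carbon, and the one step on record goes in the other direction, to a much larger group. For the measured compounds named here, with compound 2 sitting at a limit, no exact step can be drawn from it; the expectation is that compound 3 lands near the floor of this assay, with the estimated step of an at least 1.6-fold higher number from compound 2 to compound 3 (0.20 log units; that floor lies within the scatter) carrying wide uncertainty. Compound 3 is estimated at 8000 nM, within 2000 nM to 40000 nM.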

Compound 3, solubility: 80000 nM
The estimate for compound 3 lay 10-fold (1.00 log units) below the measured number, and the stated range ends below it.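

On the carbonyl carbon of the shared core, amino in place of methoxy gives an at least 16-fold higher number from compound 2 to compound 3 (1.20 log units; beyond the scatter) in this assay, so this single change, methoxycarbonyl to carbamoyl, lifts the read-out clear of the floor without the 3-aminopyrrolidin-1-yl group. Among the compounds shown here, that group keeps only a modest lead over amino, with a 2.1-fold lower number from compound 1 to compound 3 (0.31 log units; beyond the scatter), and across these three compounds the two with nitrogen on the carbonyl carbon read well above the one with oxygen there, with no compound going against this. As far as these compounds go, compound 2 stands at a limit and not a number, so the step from it is open in size on one side: the limit of < 5000 nM in this assay, at which 1 of the 3 values shown sits.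

The compounds shown leave open whether a carboxylic acid, a methylamino group or a dimethylamino group on this carbonyl carbon would read with compound 3 or with compound 2. They also leave open whether the lead of compound 1 over compound 3 follows the ring or its amino group, a question that a plain pyrrolidin-1-yl group or an open-chain aminoethylamino group at the same place would separate.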